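Swapping a triazole for a methylimidazole in compound 2

The source may report more compounds than this note shows. Statements on the series, on what has been measured and on what is new or still open speak of the compounds shown alone.

Compound 2 `CC(C)C(c1nnc[nH]1)c1ccc(-c2ccc3cccc(F)c3c2)[nH]c1=O` carries a 4H-1,2,4-triazol-3-yl group on a saturated chain carbon bound to an aromatic carbon and a saturated chain carbon. Among the measured compounds shown here, in an ADME assay on microsomes from liver (Rattus norvegicus) for metabolic stability (a lower number here means that the compound disappears faster, a higher number that the compound lasts longer), compound 2 gives 0.552 h, the only plain number among the three measured compounds. Compound 1 `CCn1ncc2c(F)cc(-c3ccc(C(CC)(CC)c4nnc[nH]4)c(=O)[nH]3)cc21` sits at the limit > 3 h in this assay. Compound 3 `CCn1ncc2c(F)cc(-c3ccc(C(CC)(CC)c4ncn(C)n4)c(=O)[nH]3)cc21` likewise sits at the limit > 3 h in this assay. These two share a core of their own and differ from each other in one place: a step that the two limits leave unreadable from compound 1 to compound 3. This step is the nearest relative of the change considered here, yet it says nothing about its size, because of the limit of > 3 h in this assay, at which 2 of the 3 values shown sit.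

Compound 4 `Cc1c[nH]c(C(c2ccc(-c3ccc4cccc(F)c4c3)[nH]c2=O)C(C)C)n1` differs from compound 2 in one place: 4-methyl-1H-imidazol-2-yl in place of 4H-1,2,4-triazol-3-yl on a saturated chain carbon bound to an aromatic carbon and a saturated chain carbon. For the measured compounds named here, no measured pair tells how such a swap plays out on the core of compound 2, so the only anchor is the value of compound 2 itself. With no readable step to lean on, no change beyond the usual scatter is expected, and compound 4 is estimated at 0.6 h, within 0.25 h to 1.5 h. The expected step of a 1.1-fold higher number from compound 2 to compound 4 (0.04 log units; within the scatter) is therefore no more than the scatter.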

Compound 4, half-life: < 0.0667 h
Compound 4 ended at the assay's limit; the forecaster's own chance of this, stated with the estimate: 5%; middle value at least 8.9-fold (0.95 log units) from the limit.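

In this assay, the place on a saturated chain carbon bound to an aromatic carbon and a saturated chain carbon now gives its first readable step, and the exchange of 4H-1,2,4-triazol-3-yl for 4-methyl-1H-imidazol-2-yl goes with an at least 8.2-fold lower number from compound 2 to compound 4 (0.91 log units; beyond the scatter). Compound 4 gives < 0.0667 h, which is a limit of the assay and not a number, so this step has a smallest size but no known full size. The result therefore shows that, on the core of compound 2, the choice of five-membered ring at this place can go with a clear loss of half-life, something the earlier compounds could not show, as the one step among them cannot be read: the limit of > 3 h in this assay, at which 2 of the 4 values shown sit.

The entering group differs from the leaving one both in its ring and in carrying a methyl, and the compounds shown do not separate these two changes, which an unsubstituted 1H-imidazol-2-yl at the same place could do. Going by these compounds, it also remains open whether the same exchange would go with a similar step on the core of compound 1.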